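Swapping a Pyridine for a Fluorinated Phenyl on the Sulfonyl

A few compounds are considered here, and "the series" means these few. Any claim that something is new, unique, unknown or untested is made for them only; others in the source may bear on it.

Compound 1 `Cc1cc(S(=O)(=O)N2CCC[C@@H]2c2ccc(F)cc2)cc(C)c1F` and compound 2 `O=S(=O)(c1cccnc1)N1[C@H](CO)CC[C@@H]1c1ccc(F)cc1` share a core. In an assay on isolated protein for inhibition of transient receptor potential cation channel subfamily A member 1 (Homo sapiens) (a lower number here means a stronger inhibitor, a higher number a weaker inhibitor), compound 1 gives 110 nM. For compound 2 the this assay reports only a limit, > 20000 nM, not a number. So compound 2 stands at the limit of > 20000 nM in this assay, at which 1 of the 2 values shown sits. Compound 3 `Cc1cc(S(=O)(=O)N2[C@H](CO)CC[C@@H]2c2ccc(F)cc2)ccc1F` differs from compound 2 by 4-fluoro-3-methylphenyl in place of pyridin-3-yl on a sulfonyl sulfur. Within the data shown here, no measured pair isolates this change, but the entering group resembles the aryl group of compound 1, which gives 110 nM. A step beyond the scatter toward stronger inhibition is expected, namely an at least 20-fold lower number from compound 2 to compound 3 (1.30 log units; beyond the scatter). Compound 3 is estimated at 1000 nM, within 150 nM to 10000 nM.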

Compound 3, half-maximal inhibitory concentration in the transient receptor potential cation channel subfamily A member 1 assay: 190 nM
Beside the measured number, compound 3's estimate is 5.3-fold (0.72 log units) above it; the measured number falls inside the stated range.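

Among these compounds, this is the first measured pair to isolate the group on the sulfonyl sulfur, and in the transient receptor potential cation channel subfamily A member 1 assay replacing pyridin-3-yl with 4-fluoro-3-methylphenyl gives an at least 100-fold lower number from compound 2 to compound 3 (2.02 log units; beyond the scatter). In the transient receptor potential cation channel subfamily A member 1 assay compound 2 has only a limit, > 20000 nM. In a physicochemical assay for lipophilicity, at pH 7.4 (a lower number here means a more polar compound, a higher number a more lipophilic compound), compound 2 gives 1.1 and compound 3 gives 2.8. Inhibition and lipophilicity rise together across this one pair, so it cannot separate the two: the measured distribution coefficient of compound 2, 1.1, and of compound 3, 2.8, a number 1.70 log units higher (beyond the scatter)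

The compounds shown leave open how much of the gain belongs to the fluorine and how much to the methyl. They also leave open how a plain phenyl, or a phenyl carrying an amine, would compare at this position.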